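Halogenated Ring Returns After a Trimethoxyphenyl Detour

The source may report more compounds than this note shows. Statements on the series, on what has been measured and on what is new or still open speak of the compounds shown alone.

Measured so far in a functional assay on A549 cells (Homo sapiens) for cytotoxicity, read by MTT assay, with a stated time of 72 h; on this read-out higher numbers stand for weaker inhibition and lower numbers for stronger inhibition:
Compound 1 `CN(C)CCn1cnnc1-c1cc(Oc2ccc(NC(=O)N/N=C/c3ccc(Cl)cc3Cl)cc2F)ccn1` gives 810 nM.
Compound 2 `COc1ccc(/C=N/NC(=O)Nc2ccc(Oc3ccnc(-c4nncn4CCN(C)C)c3)c(F)c2)c(OC)c1OC` gives 6680 nM.

Going by the values given here, compound 2 stands with the highest number of the two measured so far; its nearest neighbour is compound 1, and the step of an 8.2-fold higher number from compound 1 to compound 2 (0.92 log units; beyond the scatter) lies beyond the scatter, so compound 2 is the weaker inhibitor of the pair.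

Compound 3 `CN(C)CCn1cnnc1-c1cc(Oc2ccc(NC(=O)N/N=C/c3ccc(F)cc3F)cc2F)ccn1` has not yet been measured. It differs from compound 2 in one place: 2,4-difluorophenyl in place of 2,3,4-trimethoxyphenyl on a carbon with a double bond to nitrogen.

Among the compounds with values here, the only measured step that bears on this site is an 8.2-fold higher number from compound 1 to compound 2 (0.92 log units; beyond the scatter), in which a 2,3,4-trimethoxyphenyl group took the place of a 2,4-dichlorophenyl group and the number rose modestly. Compound 3 carries a 2,4-difluorophenyl group, so this change undoes that replacement and puts a different halogenated ring in its place. A drop in the number from compound 2, back toward the neighbourhood of compound 1, is therefore the expectation, with some uncertainty about whether fluorine matches chlorine here.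

Compound 3 is expected to give about 1500 nM in this assay, with a likely range from 500 nM to 4500 nM. This estimate implies a step of a 4.5-fold lower number from compound 2 to compound 3 (0.65 log units; beyond the scatter).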

Compound 3, half-maximal inhibitory concentration: 1870 nM
Beside the measured number, compound 3's estimate is 1.2-fold (0.10 log units) below it; measured number inside the range.
By their numbers in this assay, from the lowest: compound 1; then compound 3; then compound 2.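

In this assay, the 2,4-difluorophenyl group gives a 3.6-fold lower number from compound 2 to compound 3 (0.55 log units; beyond the scatter), so on this carbon with a double bond to nitrogen, a second dihalogenated ring also gives a lower number than the 2,3,4-trimethoxyphenyl group. This means the lower number seen with compound 1 does not belong to the 2,4-dichlorophenyl group alone. The two halogens are still not interchangeable, as changing chlorine to fluorine gives a 2.3-fold higher number from compound 1 to compound 3 (0.36 log units; beyond the scatter) and this step lies beyond the scatter, leaving the order at this position as dichloro, then difluoro, then trimethoxy. None of the data shown explains why the number moves in either step.

Going by these compounds alone, with only three rings to compare, it remains open whether the halogens lower the number themselves or whether the loss of the three methoxy groups matters more, a question that a plain phenyl ring could help settle. It is also unknown how a ring bearing a single chlorine, or one bearing a trifluoromethyl group, would compare with the 2,4-dichlorophenyl group.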